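A few compounds are considered here, and "the series" means these few. Any claim that something is new, unique, unknown or untested is made for them only; others in the source may bear on it.

Of the compounds shown here, three have so far been tested in a functional assay on RD cells (Homo sapiens) for inhibition, read by luminescence and ATP content, with a stated time of 72 h; a lower number here means that less compound is tolerated, a higher number that more compound is tolerated. Compound 1 `CCOC(=O)c1cnc2ccc(-c3ccc(C(C)C)cc3)cc2c1` gives > 7400 nM, which is a limit of the assay rather than a measured number. Compound 2 `CCCCc1nc(-c2cnc3ccc(-c4ccc(N)cc4)cc3c2)no1` gives > 2500 nM, again a limit. Compound 3 `Cc1ccc(-c2ccc3ncc(-c4noc(C(F)(F)F)n4)cc3c2)cc1` gives > 22200 nM, also a limit. Compound 3 therefore stands at a limit, as do the two other values, and none of the three can be ordered against another.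

Compound 4 `FC(F)(F)c1nc(-c2cnc3ccc(-c4ccc(Cl)cc4)cc3c2)no1` has not yet been measured. It differs from compound 3 in a single place: chloro in place of methyl on an aromatic carbon. Going by the values given here, no step between measured compounds exists to show what such a change does in this assay, so the expectation rests only on the change itself, which is small.

The step expected here is a number no higher from compound 3 to compound 4 (the limit leaves the size open), which is none beyond the scatter. Compound 4 is accordingly estimated at 22200 nM in this assay, within a range from 5000 nM to 60000 nM, and most probably again reported only as a limit.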

Compound 4, half-maximal cytotoxic concentration: > 200000 nM
Compound 4: only a limit was reported; the forecaster's own chance of this, stated with the estimate: 70%; middle value at least 9.0-fold (0.95 log units) from the limit.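

Going by these compounds alone, compound 3 and compound 4 are both reported only as limits in this assay, so no step between them can be read. The compounds shown leave open where any of the four truly stands, and whether chloro in place of methyl on an aromatic carbon changes the result at all.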